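Amide in place of phenyl on the sulfanyl chain

This account rests on a few compounds, and the source may have more. Where it says the series, first, only, none or still open, it means among the compounds named here.

Compound 3 `COc1cc(-c2nnc(SCc3ccccc3)n2-c2ccc(N(C)C)cc2)cc(OC)c1OC` carries dimethylamino where compound 1 `COc1ccc(-n2c(SCc3ccccc3)nnc2-c2cc(OC)c(OC)c(OC)c2)cc1` carries methoxy on an aromatic carbon. In a functional assay on HepG2 cells (Homo sapiens) for inhibition, read by MTT assay, with a stated time of 48 h (a lower number here means a stronger inhibitor, a higher number a weaker inhibitor), compound 3 gives only a limit of the assay, > 60000 nM. Compound 1 likewise gives only a limit in this assay, > 60000 nM. The step that the two limits leave unreadable from compound 1 to compound 3 therefore cannot be read, which rests on (the limit of > 60000 nM in this assay, at which 2 of the 3 values shown sit). Compound 2 `COc1ccc(C(=O)CSc2nnc(-c3cc(OC)c(OC)c(OC)c3)n2-c2ccc(OC)cc2)cc1`, with (4-methoxyphenyl)carbonyl in place of phenyl on the saturated chain carbon bound to a sulfur, gives 18100 nM in this assay, and the step of an at least 3.3-fold lower number from compound 1 to compound 2 (0.52 log units; beyond the scatter) is the only readable one in the set.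

Compound 4 `COc1cc(-c2nnc(SCC(=O)Nc3ccc(Cl)cc3)n2-c2ccc(N(C)C)cc2)cc(OC)c1OC` is compound 3 altered at that same place: (4-chlorophenyl)carbamoyl in place of phenyl on a saturated chain carbon bound to a sulfur. For the measured compounds named here, the change from compound 1 to compound 2 is the one comparison that bears on it: putting (4-methoxyphenyl)carbonyl on that chain carbon moved the number from a limit to a measured value. The same direction is expected for compound 4, a step of about an at least 3.0-fold lower number from compound 3 to compound 4 (0.47 log units; beyond the scatter) in this assay, though compound 3 sitting at the limit leaves the starting point itself uncertain. The estimate for compound 4 in this assay is 20000 nM, with a range of 6000 nM to 60000 nM, and a fair chance that only a limit is returned again.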

Compound 4, half-maximal inhibitory concentration: > 60000 nM
Compound 4 ended at the assay's limit; the forecaster's own chance of this, stated with the estimate: 35%; middle value at least 3.0-fold (0.47 log units) away from the limit.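

In this assay compound 4 gives > 60000 nM, which is a limit of the assay. Compound 3 also sits at a limit, so no new step can be read between compound 3 and compound 4: the limit of > 60000 nM in this assay, at which 3 of the 4 values shown sit.

The compounds shown leave open whether (4-chlorophenyl)carbamoyl in place of phenyl on a saturated chain carbon bound to a sulfur changes the number at all.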